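The source may report more compounds than this note shows. Statements on the series, on what has been measured and on what is new or still open speak of the compounds shown alone.

Within the data shown here, in an assay on isolated protein for displacement of a labelled ligand from metabotropic glutamate receptor 5 (Homo sapiens), with a stated time of 60 min, tested at 1 uM (a lower number here means less inhibition, a higher number more inhibition at the concentration tested (going by the name of the read-out)), compound 2 `Cc1cc(C)cc(S(=O)(=O)c2cnc3ccc(C)cc3c2N2CCC(C)CC2)c1` gives 80%, the second highest of the three numbers so far: compound 3 `Cc1cc(C)cc(S(=O)(=O)c2cnc3ccc(F)cc3c2N2CCC(C)CC2)c1` gives 83%, with a number 3 percentage points higher from compound 2 to compound 3 (within the scatter), and compound 1 `Cc1ccc2ncc(S(=O)(=O)c3cccc(C#N)c3)c(N3CCC(C)CC3)c2c1` gives 52%, with a number 28 percentage points higher from compound 1 to compound 2 (beyond the scatter). Compound 4 `Cc1ccc2ncc(S(=O)(=O)c3cccc(Cl)c3)c(N3CCC(C)CC3)c2c1` differs from compound 2 by 3-chlorophenyl in place of 3,5-dimethylphenyl on a sulfonyl sulfur. Among the measured compounds shown here, the only measured step at the sulfonyl sulfur is a number 28 percentage points higher from compound 1 to compound 2 (beyond the scatter), a modest gain on going from 3-cyanophenyl to 3,5-dimethylphenyl; the change to compound 4 removes the 3,5-dimethylphenyl again for another singly substituted ring, so a fall toward the reading of compound 1 is expected, smaller than that step. The expected step is a number 15 percentage points lower from compound 2 to compound 4 (beyond the scatter). Compound 4 is estimated at 65% in this assay, with a range from 45% to 82%.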

Compound 4, a percentage reported as inhibition, at one concentration (the size of the read-out at that concentration, not a potency): 91%
The estimate for compound 4 lay 26 percentage points below the measured number, outside the stated range (above it).
By their numbers in this assay, from the lowest: compound 1; then compounds 2, 3 and 4 (each within the scatter of the next, the first and the last beyond it).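

Within the series, the 3,5-dimethylphenyl on the sulfonyl sulfur is not needed for a high reading in this assay, with a number 11 percentage points higher from compound 2 to compound 4 (beyond the scatter) on moving to 3-chlorophenyl. Among the singly substituted rings, the choice of group matters greatly, with a number 39 percentage points higher from compound 1 to compound 4 (beyond the scatter) for chloro in place of cyano, so across compound 1, compound 2 and compound 4 the number of substituents does not set the reading. Nothing available explains either step.

Open, on these data alone, is whether a methoxy group or an amine on this ring would read like chloro or like cyano. Also open, as far as these compounds go, is how 3-chlorophenyl behaves with fluoro in place of methyl on the shared core.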